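Three cinnamamides on a shared core, and a propargyl ether

A few compounds are considered here, and "the series" means these few. Any claim that something is new, unique, unknown or untested is made for them only; others in the source may bear on it.

Measured in a functional assay on PC-3 cells (Homo sapiens) for cytotoxicity, read by MTT assay, with a stated time of 72 h; a lower number here means a stronger inhibitor, a higher number a weaker inhibitor:
- compound 1 `COc1ccc(/C=C/C(=O)Nc2cc(C(=O)c3cc(OC)c(OC)c(OC)c3)cc(OC)c2OC)cc1OC`: 5400 nM
- compound 2 `COc1cccc(/C=C/C(=O)Nc2cc(C(=O)c3cc(OC)c(OC)c(OC)c3)cc(OC)c2OC)c1`: 13300 nM
- compound 3 `COc1ccc(/C=C/C(=O)Nc2cc(C(=O)c3cc(OC)c(OC)c(OC)c3)cc(OC)c2OC)cc1N`: 11100 nM

Compound 3 sits second highest of the three numbers. Its nearest neighbour is compound 2, with a 1.2-fold lower number from compound 2 to compound 3 (0.08 log units; within the scatter), a gap that stays inside the usual scatter. The furthest is compound 1, from which a 2.1-fold higher number from compound 1 to compound 3 (0.31 log units; beyond the scatter); the related change from compound 1 gives a 2.5-fold higher number from compound 1 to compound 2 (0.39 log units; beyond the scatter).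

Compound 4 `C#CCOc1cccc(/C=C/C(=O)Nc2cc(C(=O)c3cc(OC)c(OC)c(OC)c3)cc(OC)c2OC)c1` has not been measured. It differs from compound 3 in one place: 3-(propargyloxy)phenyl in place of 3-amino-4-methoxyphenyl on a double-bonded chain carbon bound to a double-bonded chain carbon. In effect compound 4 resembles compound 2, with the methoxy on the outer ring grown into a propargyloxy, while the amino and the second methoxy of compound 3 are gone. Going by the values given here, no measured step shows what lengthening that ether does. Among the compounds with values here, the steps that bear on it are the removal of the extra methoxy, a 2.5-fold higher number from compound 1 to compound 2 (0.39 log units; beyond the scatter), and the swap of amino for methoxy, a 2.1-fold higher number from compound 1 to compound 3 (0.31 log units; beyond the scatter), both modest, while the difference between compound 2 and compound 3 lies within the scatter.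

In this assay compound 4 is therefore expected to land close to compound 2, with a 1.1-fold higher number from compound 3 to compound 4 (0.05 log units; within the scatter) as the estimated step, not clearly beyond the scatter. The estimate for compound 4 is 12500 nM, within a range of 5000 nM to 32000 nM.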

Compound 4, half-maximal inhibitory concentration: 10100 nM
Beside the measured number, compound 4's estimate is 1.2-fold (0.09 log units) above it, within the range that was stated.
By their numbers in this assay, from the lowest: compounds 1, 4, 3 and 2 (each within the scatter of the next, the first and the last beyond it).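

Growing the methoxy on the outer ring into a propargyloxy, with ethynyl in place of hydrogen on a saturated chain carbon bound to an oxygen on an aromatic ring, gives a 1.3-fold lower number from compound 2 to compound 4 (0.12 log units; within the scatter) in this assay, so this longer ether leaves the reading inside the usual scatter. The larger exchanges at the same place, on a double-bonded chain carbon bound to a double-bonded chain carbon, also stay inside it: 3-(propargyloxy)phenyl in place of 3-amino-4-methoxyphenyl gives a 1.1-fold lower number from compound 3 to compound 4 (0.04 log units; within the scatter), and in place of 3,4-dimethoxyphenyl it gives a 1.9-fold higher number from compound 1 to compound 4 (0.27 log units; within the scatter), whereas the loss of one methoxy alone gave a 2.5-fold higher number from compound 1 to compound 2 (0.39 log units; beyond the scatter). No evidence is at hand on what lies behind these readings.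

The compounds shown leave open whether a benzyl ether or a chain ending in a carboxylic acid on the same oxygen would also stay within the scatter. They also leave open how a propargyloxy would read alongside a second methoxy or an amino on the same ring, as those groups appear in compound 1 and compound 3.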